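The source may hold more compounds than are shown below. What is called first, only, known or untested is meant among the compounds shown, and "the series" means these compounds.

Three members of this series have been measured in an assay on isolated protein for inhibition of Aromatase (Homo sapiens), read by fluorescence, with a stated time of 10 min, tested at 12.5 uM; a lower number here means less inhibition, a higher number more inhibition at the concentration tested (going by the name of the read-out). Compound 1 `O=c1ccc2ccc(OCc3cn(-c4cccc(S(=O)(=O)N5CCc6ccccc6C5)c4)nn3)cc2o1` gives 14%, compound 2 `COc1cc2c(cc1OC)CN(S(=O)(=O)c1cccc(-n3cc(COc4ccc5ccc(=O)oc5c4)nn3)c1)CC2` gives 14% in this assay, and compound 3 `COc1cc2c(cc1OC)CN(S(=O)(=O)c1ccc(-n3cc(COc4cc(C=O)ccc4OC)nn3)cc1)CC2` gives 14% in this assay. Compound 3 stands level with compound 1 and compound 2 at the digits shown, the gaps lying within the usual scatter. Compound 4 `COc1cc2c(cc1OC)CN(S(=O)(=O)c1ccc(-n3cc(COc4ccccc4C(C)=O)nn3)cc1)CC2` has not yet been measured. It differs from compound 3 in one place: 2-acetylphenyl in place of 5-formyl-2-methoxyphenyl on an oxygen on a saturated carbon. Going by the values given here, no step between measured compounds is available to size this change. In this assay the expected step is no change at the digits printed from compound 3 to compound 4 (within the scatter), none beyond the scatter. Compound 1, compound 2 and compound 3 all sit at one level. Compound 4 is therefore expected to give about 14%, between 4% and 26%.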

Compound 4, a percentage reported as inhibition, at one concentration (the size of the read-out at that concentration, not a potency): 14%
Estimate against measurement, compound 4: no gap at the digits printed; the measured number falls inside the stated range.
By their numbers in this assay, from the lowest: compounds 1, 2, 3 and 4 (each within the scatter of the next).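

In this assay, going by these compounds alone, 2-acetylphenyl in place of 5-formyl-2-methoxyphenyl on an oxygen on a saturated carbon gives no change at the digits printed from compound 3 to compound 4 (within the scatter) as the only step readable so far. The number therefore stays level at this single concentration across a swap from 2 hydrogen-bond acceptors to 1 in the group at this place. No available measurement offers an explanation for this flat step.

Still open, from the compounds shown here alone, is whether a phenyl group carrying an amine or a carboxylic acid at this place would move the read-out beyond the scatter.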